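Trifluoromethyl on the pyrazole ring of a glucagon receptor ligand

The compounds below may be only part of what the source reports. "The series", "measured", "known", "first", "only" and "open" are said of these compounds alone.

Measured compounds:
Compound 1 `O=C(O)CCNC(=O)c1ccc(C(Oc2ccc(-n3cc(C(F)(F)F)cn3)cc2)C2CC2)cc1`: 1300 nM
Compound 2 `CCCC(Oc1ccc(-n2cc(C#N)cn2)cc1)c1ccc(C(=O)NCCC(=O)O)cc1`: 4100 nM
Compound 3 `CCCC(Oc1ccc(-n2cccn2)cc1)c1ccc(C(=O)NCCC(=O)O)cc1`: 4100 nM

In an assay on cells for displacement of a labelled ligand from Glucagon receptor (Homo sapiens), in the presence of a further agent that is not named here (on this read-out lower numbers stand for stronger inhibition and higher numbers for weaker inhibition), compound 3 gives 4100 nM, level with compound 2 and together with it the highest of the three numbers; compound 1 lies furthest away with a number that is lower beyond the scatter. Among the measured compounds shown here, the only single-point step among the measured compounds, no change at the digits printed from compound 2 to compound 3 (within the scatter), shows no change within the scatter.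

Compound 4 `CCCC(Oc1ccc(-n2cc(C(F)(F)F)cn2)cc1)c1ccc(C(=O)NCCC(=O)O)cc1` differs from compound 3 by trifluoromethyl in place of hydrogen on an aromatic carbon, the change reading 1H-pyrazol-1-yl to 4-(trifluoromethyl)-1H-pyrazol-1-yl. For the measured compounds named here, no measured step covers exactly this exchange. Compound 1 also carries the trifluoromethyl group, but it differs from compound 4 in a second place as well, so its lower value is only a loose guide. The nitrile-to-hydrogen step left this assay unchanged, which argues for a small effect of substitution at this carbon. A modest step toward a lower number, a 1.9-fold lower number from compound 3 to compound 4 (0.27 log units; within the scatter), is therefore expected. Compound 4 is estimated to give 2200 nM, within a range from 900 nM to 5000 nM.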

Compound 4, inhibition constant: 890 nM
Estimate against measurement, compound 4: 2.5-fold (0.39 log units) above; the measured number lies below the stated range.
By their numbers in this assay, from the lowest: compounds 4 and 1 (each within the scatter of the next); then compounds 2 and 3 (each within the scatter of the next).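

At this carbon of the pyrazole ring, the group does matter in this assay: trifluoromethyl in place of hydrogen gives a 4.6-fold lower number from compound 3 to compound 4 (0.66 log units; beyond the scatter) and trifluoromethyl in place of nitrile gives a 4.6-fold lower number from compound 2 to compound 4 (0.66 log units; beyond the scatter), although the exchange of nitrile for hydrogen had given no change at the digits printed from compound 2 to compound 3 (within the scatter). The earlier pair therefore hid a difference at this position, which appears only with trifluoromethyl. With trifluoromethyl held in place, propyl in place of cyclopropyl gives a 1.5-fold lower number from compound 1 to compound 4 (0.16 log units; within the scatter), so the low number of compound 1 does not depend on its cyclopropyl group.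

Nothing available here gives a reason for the trifluoromethyl step. On these data alone, whether a methyl group, a chlorine atom or a longer fluorinated chain at this carbon would act like trifluoromethyl remains open.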